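Cyano in place of ethyl at the phenoxy terminus

The source may hold more compounds than are shown below. What is called first, only, known or untested is meant among the compounds shown, and "the series" means these compounds.

Measured compounds in an assay on cells for activation of probable G-protein coupled receptor 34 (Mus musculus), with a stated time of 1 h; a higher number here means a larger maximal response, a lower number a smaller maximal response:
compound 1 `N[C@@H](COP(=O)(O)OCCCOC(=O)CCc1ccccc1OCc1cccc(Oc2ccccc2)c1)C(=O)O` gives 0.48
compound 2 `N[C@@H](COP(=O)(O)OCCCOC(=O)CCc1ccccc1OCc1cccc(Oc2ccc(I)cc2)c1)C(=O)O` gives 0.82
compound 3 `CCc1ccc(Oc2cccc(COc3ccccc3CCC(=O)OCCCOP(=O)(O)OC[C@H](N)C(=O)O)c2)cc1` gives 0.42

Compound 3 stands lowest of the three numbers in this assay, yet its gap to compound 1 lies within the scatter; only compound 2 sits clearly apart, the step being a number 0.40 lower from compound 2 to compound 3 (beyond the scatter).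

Compound 4 `N#Cc1ccc(Oc2cccc(COc3ccccc3CCC(=O)OCCCOP(=O)(O)OC[C@H](N)C(=O)O)c2)cc1` differs from compound 3 in one place: cyano in place of ethyl on an aromatic carbon.

Among the measured compounds shown here, no measured step exchanges cyano for another group, so the bearing steps are indirect. The step a number 0.060 lower from compound 1 to compound 3 (within the scatter) shows that ethyl at this carbon leaves the response where hydrogen leaves it. The step a number 0.34 higher from compound 1 to compound 2 (beyond the scatter) shows that iodo at the same carbon gives a large rise. Whether cyano behaves like ethyl or like iodo cannot be read from these three compounds; a modest rise is expected because a number 0.34 higher from compound 1 to compound 2 (beyond the scatter) is the only substituted case that moved at all, tempered by the flat result of compound 3.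

The expected step is a number 0.13 higher from compound 3 to compound 4 (beyond the scatter). Compound 4 is therefore estimated at 0.55, with a range from 0.3 to 0.85.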

Compound 4, intrinsic activity: the largest response reached, as a fraction of the reference agonist's: 0.041
The estimate for compound 4 lay 0.51 above the measured number, and the stated range ends above it.
By their numbers in this assay, from the lowest: compound 4; then compounds 3 and 1 (each within the scatter of the next); then compound 2.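

In this assay, the carbon para to a large group proves able to lower the maximal response as well as raise it: the 4-cyanophenoxy terminus falls clearly below the unsubstituted one (a number 0.44 lower from compound 1 to compound 4 (beyond the scatter)). Ethyl and cyano have the same count of heavy atoms, yet exchanging them gives a large fall (a number 0.38 lower from compound 3 to compound 4 (beyond the scatter)), and the iodo-to-cyano exchange at this one carbon gives a larger fall still (a number 0.78 lower from compound 2 to compound 4 (beyond the scatter)). No measured data on these compounds account for the fall.

From the compounds shown here alone, whether the low response is particular to cyano or extends to other groups at this carbon, such as a carboxylic acid or an amine, stays open. Equally open, going by these compounds, is whether bromo or chloro here would follow iodo, ethyl or cyano.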